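The source may hold more compounds than are shown below. What is called first, only, known or untested is meant among the compounds shown, and "the series" means these compounds.

In a functional assay on HL-60 cells (Homo sapiens) for inhibition, read by MTT assay, with a stated time of 72 h (a lower number here means a stronger inhibitor, a higher number a weaker inhibitor), three related compounds have been measured: compound 1 `Cc1nc(-c2ccccc2)c(C(=O)N2CCN(c3cccc(Cl)c3)CC2)o1` gives 39.2 nM while compound 2 `COc1cccc(N2CCN(C(=O)c3oc(C)nc3-c3ccccc3F)CC2)c1` gives 56.1 nM and compound 3 `Cc1ccc(N2CCN(C(=O)c3oc(C)nc3-c3ccccc3)CC2)c(C)c1` gives 101 nM in the same test. Compound 3 lies within the usual scatter of compound 2. Its gap to compound 1 goes beyond the scatter, and a 2.6-fold higher number from compound 1 to compound 3 (0.41 log units; beyond the scatter) is a modest step, made by putting 2,4-dimethylphenyl in place of 3-chlorophenyl.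

Compound 4 `COc1cccc(N2CCN(C(=O)c3oc(C)nc3-c3ccccc3)CC2)c1` changes that same spot on an amine nitrogen in a ring, with 3-methoxyphenyl in place of 2,4-dimethylphenyl on an amine nitrogen in a ring and the rest of compound 3 untouched. Among the measured compounds shown here, only that one measured step bears directly on this spot. Compound 2 also carries 3-methoxyphenyl, and its 56.1 nM is the closest guide, although it differs from compound 4 elsewhere in the molecule. A modest move toward a lower number in this assay is therefore expected, close to the size of the scatter. The estimated step is a 1.7-fold lower number from compound 3 to compound 4 (0.24 log units; within the scatter) overall. Compound 4 is expected at 58 nM with an estimated range from 25 nM to 130 nM in this test.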

Compound 4, half-maximal inhibitory concentration: 34.8 nM
Compound 4: the middle estimate sits 1.7-fold (0.22 log units) above what was measured; the measured number falls inside the stated range.
By their numbers in this assay, from the lowest: compounds 4, 1, 2 and 3 (each within the scatter of the next, the first and the last beyond it).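

In this assay there is now a 2.9-fold lower number from compound 3 to compound 4 (0.46 log units; beyond the scatter) and, together with a 2.6-fold higher number from compound 1 to compound 3 (0.41 log units; beyond the scatter), this sets 2,4-dimethylphenyl apart from both 3-methoxyphenyl and 3-chlorophenyl at this spot on the amine nitrogen. Methoxy in place of chloro on the aromatic carbon gives a 1.1-fold lower number from compound 1 to compound 4 (0.05 log units; within the scatter) and hydrogen in place of fluoro on an aromatic carbon gives a 1.6-fold lower number from compound 2 to compound 4 (0.21 log units; within the scatter) so neither change can be told apart from ordinary repeat variation in this test. Nothing available explains why the numbers differ as they do.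

The compounds shown leave open how a phenyl ring carrying a nitrile, a trifluoromethyl group or an amine would read at this spot. They also leave open whether a carboxylic acid or a longer chain would be tolerated there.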